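A methyl group on two cores in an ovarian cancer cell assay

The source may hold more compounds than are shown below. What is called first, only, known or untested is meant among the compounds shown, and "the series" means these compounds.

Measured compounds:
- compound 1, `C/C(=C\c1cc(-c2ccccc2)co1)C(N)=O`, gives 42400 nM in a functional assay on HO8910 cells (Homo sapiens) for cytotoxicity, read by CCK-8 assay, with a stated time of 24 h; on this read-out lower numbers stand for stronger inhibition and higher numbers for weaker inhibition
- compound 2, `C/C(=C\c1cc(-c2ccc(C)cc2)co1)C(N)=O`, gives 24200 nM in this assay
- compound 3, `C/C(=C\c1nc(-c2ccccc2)cs1)C(N)=O`, gives 3780 nM in this assay

Compounds 1 and 2 share one core, and compound 3 carries a different core; the difference between the two cores is not broken down here. Compound 3 stands lowest of the three, and its numbers against compound 2 and compound 1 are both beyond the scatter.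

The change from compound 1 to compound 2 is methyl in place of hydrogen on an aromatic carbon. Its effect was a 1.8-fold lower number from compound 1 to compound 2 (0.24 log units; within the scatter), so the methyl did not move the number beyond what repeated measurements would give.

Compound 4, `C/C(=C\c1nc(-c2ccc(C)cc2)cs1)C(N)=O`, is not yet measured. It differs from compound 3 by methyl in place of hydrogen on an aromatic carbon, which is the same change as that from compound 1 to compound 2, in the same place. Among the measured compounds shown here, with only one earlier instance to go on, the expectation for compound 4 is a step of about a 1.5-fold lower number from compound 3 to compound 4 (0.18 log units; within the scatter) in this assay, matching the earlier change in direction and size, because the earlier step was a 1.8-fold lower number from compound 1 to compound 2 (0.24 log units; within the scatter) and compound 3 starts from 3780 nM. Compound 4 is therefore estimated at 2500 nM in this assay, likely between 1200 nM and 6000 nM.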

Compound 4, half-maximal inhibitory concentration: > 50000 nM
Compound 4: only a limit was reported; the forecaster's own chance of this, stated with the estimate: 3%; middle value at least 20-fold (1.30 log units) away from the limit.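

Compound 4 reads > 50000 nM in this assay, which is a limit of the assay and not a number, so the change on this core, an at least 13-fold higher number from compound 3 to compound 4 (1.12 log units; beyond the scatter), gives only the smallest size the step can have. Even with that limit, methyl in place of hydrogen on an aromatic carbon does not carry over from one core to the other in this series, and a step measured on one core cannot safely be copied to the other: the same change on two cores in this assay, a 1.8-fold lower number (0.24 log units; within the scatter) from compound 1 to compound 2 and an at least 13-fold higher number (1.12 log units; beyond the scatter) from compound 3 to compound 4, at least 23-fold (1.36 log units) apart, beyond the scatter of two such steps

As far as these compounds go, what this does not show is why the two cores answer so differently, since a single pair on each core offers a comparison but no explanation, and how far compound 4 lies past its limit also remains unknown.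

The compounds shown leave open whether this break belongs to methyl alone or would also appear with another group in the same place, such as chloro, methoxy or hydroxyl, made on both cores. They also leave open whether the same split between the cores would appear with a change elsewhere in the molecule, for example a carboxylic acid in place of the primary amide.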